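This account rests on a few compounds, and the source may have more. Where it says the series, first, only, none or still open, it means among the compounds named here.

Measured so far:
- compound 1, `Cc1cnc(Nc2ccc(Cl)cc2)nc1Nc1nc2ccccc2s1`: > 50000 nM
- compound 2, `CS(=O)(=O)c1ccc(Nc2nccc(Nc3nc4ccc(Cl)cc4s3)n2)cc1`: 1350 nM

In a functional assay on HCT-116 cells (Homo sapiens) for antiproliferative activity, read by MTT assay, with a stated time of 48 h (on this read-out lower numbers stand for stronger inhibition and higher numbers for weaker inhibition), compound 1 gives no number at all, only a limit, > 50000 nM. That limit is where compound 1 stands, because the limit of > 50000 nM in this assay, at which 1 of the 2 values shown sits, marks the edge of what this assay can report rather than a measured strength. Within the data shown here, compound 2, built on a different core and carrying a different group on its aryl amine, gives 1350 nM in this assay, a real number; no single step connects it to compound 1, so the two values only show that one compound is measurable and the other is not.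

Compound 3, `Cc1cnc(Nc2ccc(F)cc2)nc1Nc1nc2ccccc2s1`, has not yet been measured. It differs from compound 1 in one place: fluoro in place of chloro on an aromatic carbon. A change this small is expected to move the value little, so the step from compound 1 to compound 3 is estimated at a number no higher from compound 1 to compound 3 (the limit leaves the size open), none beyond the scatter. Compound 3 is therefore expected to give about 50000 nM in this assay, between 15000 nM and 100000 nM, most likely again as a limit.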

Compound 3, half-maximal inhibitory concentration: > 50000 nM
Compound 3 was reported as a limit (the forecaster's own chance of this, stated with the estimate: 75%); the middle value sits exactly at the limit.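

Among these compounds, compound 1 and compound 3 are both reported only as a limit, so no step between them can be read: the limit of > 50000 nM in this assay, at which 2 of the 3 values shown sit. The compounds shown leave open whether fluoro in place of chloro changes the strength of inhibition at all in this assay.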